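Notes on ester variation, compound 1 to compound 4

The source may hold more compounds than are shown below. What is called first, only, known or untested is meant among the compounds shown, and "the series" means these compounds.

For the measured compounds named here, in a functional assay on NFS-60 cells (Mus musculus) for inhibition, read by MTT assay, with a stated time of 72 h (on this read-out lower numbers stand for stronger inhibition and higher numbers for weaker inhibition), compound 1 `COc1ccc(C(=O)OC2(C(=O)Nc3ccc([N+](=O)[O-])cc3)CCCCC2)cc1` gives 38.8 nM, the lowest of the three numbers measured so far. Compound 2 `O=C(/C=C/c1ccccc1)OC1(C(=O)Nc2ccc([N+](=O)[O-])cc2)CCCCC1` gives 50.5 nM in this assay, and compound 3 `CC(=O)OC1(C(=O)Nc2ccc([N+](=O)[O-])cc2)CCCCC1` gives 517 nM. The step of a 1.3-fold higher number from compound 1 to compound 2 (0.11 log units; within the scatter) shows that exchanging the 4-methoxyphenyl ester for the 2-phenylethenyl ester leaves the number where it stands, whereas a 13-fold higher number from compound 1 to compound 3 (1.12 log units; beyond the scatter) and a 10-fold higher number from compound 2 to compound 3 (1.01 log units; beyond the scatter) show that trimming the ester down to methyl costs a good deal.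

Compound 4 `CC(=O)Oc1ccccc1C(=O)OC1(C(=O)Nc2ccc([N+](=O)[O-])cc2)CCCCC1` has not yet been measured in this assay. It differs from compound 1 by 2-acetoxyphenyl in place of 4-methoxyphenyl on a carbonyl carbon. The aromatic ring of the ester is kept; what sits on it changes. The measured steps that bear on this are the two exchanges of the 4-methoxyphenyl ester: the small step of a 1.3-fold higher number from compound 1 to compound 2 (0.11 log units; within the scatter) suggests that an aromatic or extended ester is tolerated, and the loss seen in a 13-fold higher number from compound 1 to compound 3 (1.12 log units; beyond the scatter) came only when the ring was removed altogether, which does not happen here. A step no larger than the scatter is therefore expected. No ring substituted in this way has yet been measured, and the expectation carries a slight lean toward a higher number. Compound 4 is estimated at 55 nM (20 nM to 150 nM), which corresponds to an expected step of a 1.4-fold higher number from compound 1 to compound 4 (0.15 log units; within the scatter).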

Compound 4, half-maximal inhibitory concentration: 11.3 nM
Compound 4: the middle estimate sits 4.9-fold (0.69 log units) above what was measured; measured number below the stated range.
By their numbers in this assay, from the lowest: compound 4; then compounds 1 and 2 (each within the scatter of the next); then compound 3.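

In this assay the ester position proves able to go beyond the level shared by compounds 1 and 2: 2-acetoxyphenyl in place of 4-methoxyphenyl gives a clear gain (a 3.4-fold lower number from compound 1 to compound 4 (0.54 log units; beyond the scatter)), and 2-acetoxyphenyl in place of 2-phenylethenyl gives a similar one (a 4.5-fold lower number from compound 2 to compound 4 (0.65 log units; beyond the scatter)). Compounds 1 and 4 each carry one six-membered aromatic ring here, so the presence of the ring does not by itself set the number, and what stands on that ring can separate two aryl esters. The span at this position is also wider than the earlier compounds showed (a 46-fold lower number from compound 3 to compound 4 (1.66 log units; beyond the scatter)), and no measurement is available that explains the gain.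

The compounds shown leave open whether the gain belongs to the acetoxy group as such or to its place on the ring, a question that 2-hydroxyphenyl, 2-methoxyphenyl or 4-acetoxyphenyl at this position would address. Also open, from the compounds shown here alone, is how a ring bearing a carboxylic acid or an ester with a longer chain would fall against compound 4.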